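Cyclopentylsulfanyl for Benzylamino: Tolerance in Fibroblasts

A few compounds are considered here, and "the series" means these few. Any claim that something is new, unique, unknown or untested is made for them only; others in the source may bear on it.

Compound 1 `CCCCSc1nc(N)nc2c1ncn2/C=C1/CC1(CO)CO`: in an ADME assay on HFF cells (Homo sapiens) for cytotoxicity, with a stated time of 8 days (a higher number here means that more compound is tolerated, a lower number that less compound is tolerated), compound 1 reaches only the assay limit, > 300000 nM.
Compound 2 `Nc1nc(NCc2ccccc2)c2ncn(/C=C3/CC3(CO)CO)c2n1`: in this assay compound 2 reaches only the assay limit, > 300000 nM.
Compound 3 `CCCCNc1nc(N)nc2c1ncn2/C=C1/CC1(CO)CO`: in this assay compound 3 reaches only the assay limit, > 300000 nM.

Compound 2 therefore stands at a limit rather than at a number, and the other two measured compounds stand at the same limit, since (the limit of > 300000 nM in this assay, at which 3 of the 3 values shown sit). Every value is a limit. For the measured compounds named here, the steps a step that the two limits leave unreadable from compound 1 to compound 2, a step that the two limits leave unreadable from compound 1 to compound 3 and a step that the two limits leave unreadable from compound 2 to compound 3 cannot be sized; they show only that no compound among the three was toxic within the tested range.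

Compound 4 `Nc1nc(SC2CCCC2)c2ncn(/C=C3/CC3(CO)CO)c2n1` differs from compound 2 in one place: cyclopentylsulfanyl in place of benzylamino on an aromatic carbon. The closest measured comparison is the swap of butylsulfanyl for benzylamino, but that step is unreadable, so no direction or size can be drawn from it for this assay. Given that all three measured compounds sit at the limit, compound 4 is expected to behave alike, with an estimated step of a number no higher from compound 2 to compound 4 (the limit leaves the size open). The estimate for compound 4 is 300000 nM, ranging from 100000 nM to 600000 nM, most likely reported again as a limit.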

Compound 4, half-maximal cytotoxic concentration: > 300000 nM
Compound 4 gave a limit, no number; the forecaster's own chance of this, stated with the estimate: 85%; the middle value sits exactly at the limit.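

No step can be read between compound 4 and compound 1, compound 2 or compound 3, since all four stand at a limit rather than a number: the limit of > 300000 nM in this assay, at which 4 of the 4 values shown sit.

The compounds shown leave open at what concentration any of them would harm the cells in this assay, and whether the groups that differ on the shared core change tolerance at all.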